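The compounds below may be only part of what the source reports. "The series", "measured", "known", "first", "only" and "open" are said of these compounds alone.

Compound 2 `O=C(COc1ccc2cc(/C=C3/SC(=O)NC3=O)ccc2c1)Nc1cccc(Cl)c1` carries a 3-chlorophenyl on an amide-type nitrogen. In an assay on isolated protein for inhibition of histone deacetylase 8 (Homo sapiens), with a stated time of 1 h (on this read-out higher numbers stand for weaker inhibition and lower numbers for stronger inhibition), compound 2 reaches only > 50000 nM, which is a limit of the measurement and not a number. Compound 1 `O=C(COc1ccc2cc(/C=C3/SC(=O)NC3=O)ccc2c1)Nc1ccc(F)cc1`, which bears a 4-fluorophenyl at the same place, gives 6600 nM in this assay. For the measured compounds named here, the only measured step is an at least 7.5-fold higher number from compound 1 to compound 2 (0.87 log units; beyond the scatter), and its size is known only as a lower bound, since (the limit of > 50000 nM in this assay, at which 1 of the 2 values shown sits). Compound 3 `O=C(COc1ccc2cc(/C=C3/SC(=O)NC3=O)ccc2c1)Nc1ccc(Br)cc1` differs from compound 2 by 4-bromophenyl in place of 3-chlorophenyl on an amide-type nitrogen. Going by the values given here, no measured step exchanges these two groups directly, so the expectation leans on compound 1, whose 4-fluorophenyl gave a number rather than a limit. A return toward the potency of compound 1 is therefore expected, but with wide uncertainty. For compound 3 the estimate is 15000 nM, within the range 4000 nM to 60000 nM, which is expected to correspond to an at least 3.3-fold lower number from compound 2 to compound 3 (0.52 log units; beyond the scatter).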

Compound 3, half-maximal inhibitory concentration: 16000 nM
For compound 3 the middle estimate is 1.1-fold (0.03 log units) below the measured one, within the range that was stated.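

In this assay, a group on the amide-type nitrogen other than 4-fluorophenyl can still give a measurable number, with an at least 3.1-fold lower number from compound 2 to compound 3 (0.49 log units; beyond the scatter), a size known only as a lower bound. Compound 2 stands at a limit of the assay and not at a number: the limit of > 50000 nM in this assay, at which 1 of the 3 values shown sits. The cleaner comparison is bromo in place of fluoro on an aromatic carbon, with a 2.4-fold higher number from compound 1 to compound 3 (0.38 log units; beyond the scatter), so the identity of the halogen alone changes the read-out, and fluoro gives the stronger inhibition of these two.

Compound 2 differs from compound 3 in both the halogen and its place on the ring, so the two contributions remain tangled, and a 4-chlorophenyl would help separate them. As far as these compounds go, it also remains open how a plain phenyl or a 4-aminophenyl would behave here.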